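This account rests on a few compounds, and the source may have more. Where it says the series, first, only, none or still open, it means among the compounds named here.

Measured compounds:
compound 1, `O=C(CSc1nc2c(c(=O)n1-c1ccccc1)SCC2)Nc1ccc(-c2ccccn2)cc1`: 4 nM
compound 2, `O=C(CSc1nc2c(c(=O)n1-c1ccc(F)cc1)SCC2)Nc1nc2ccc(Cl)cc2s1`: 175 nM

In an assay on L cells for inhibition of Protein-serine O-palmitoleoyltransferase porcupine (Mus musculus), read by reporter gene assay, with a stated time of 24 h (a higher number here means that more compound is needed for the effect, a lower number that less compound is needed), compound 1 gives 4 nM, the lower of the two numbers obtained so far. Compound 2 (`O=C(CSc1nc2c(c(=O)n1-c1ccc(F)cc1)SCC2)Nc1nc2ccc(Cl)cc2s1`) gives 175 nM, and the gap between compound 1 and compound 2 lies beyond the scatter of repeat measurements; the two compounds differ in more than one place, so nothing can be attributed to any single change between them. The unmeasured compound 3 (`O=C(CSc1nc2c(c(=O)n1-c1ccccc1)SCC2)Nc1ccc(-c2ccccc2)cc1`) departs from compound 1 in one place only: phenyl in place of pyridin-2-yl on an aromatic carbon. Among the compounds with values here, no pair of measured compounds shows this single change, so its effect cannot be read from a measured step and has to be anticipated from compound 1 alone. A modest loss is expected, small enough that the result may still fall close to the scatter. Compound 3 is expected in this assay at 15 nM, within 4 nM to 60 nM. This corresponds to an expected step of a 3.8-fold higher number from compound 1 to compound 3 (0.57 log units; beyond the scatter).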

Compound 3, half-maximal effective concentration: 0.75 nM
The estimate for compound 3 lay 20-fold (1.30 log units) above the measured number; the measured number lies below the stated range.
By their numbers in this assay, from the lowest: compound 3; then compound 1; then compound 2.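

In this assay, replacing pyridin-2-yl with phenyl, para to a large group, gives a 5.3-fold lower number from compound 1 to compound 3 (0.73 log units; beyond the scatter). This shows that the ring nitrogen of pyridin-2-yl, and with it the single hydrogen-bond acceptor counted in that group, is not required at this position for a low number, and that a six-membered aromatic ring of carbon only serves better here. Nothing on hand accounts for the direction or size of this step.

The compounds shown leave open how a saturated ring such as morpholine, or a phenyl carrying an amine or a carboxylic acid, would behave at this position. They also leave open whether the same change would give a step of similar size on the rest of compound 2.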